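This account rests on a few compounds, and the source may have more. Where it says the series, first, only, none or still open, it means among the compounds named here.

Measured so far in an assay on CHO cells for displacement of a labelled ligand from Substance-P receptor (Homo sapiens), in the presence of a further agent that is not named here; a lower number here means a stronger inhibitor, a higher number a weaker inhibitor:
compound 1 `C[C@@H](O[C@H]1CN2C(=O)C=C(c3ccc(C#N)cc3)CC2[C@@H]1c1ccc(F)cc1)c1cc(C(F)(F)F)cc(C(F)(F)F)c1`, 53 nM
compound 2 `CCc1noc(C2=CC(=O)N3C[C@H](O[C@H](C)c4cc(C(F)(F)F)cc(C(F)(F)F)c4)[C@@H](c4ccc(F)cc4)C3C2)n1`, 27 nM

Going by the values given here, compound 2 has the lowest of the two numbers in this assay, yet the only step to it, a 2.0-fold lower number from compound 1 to compound 2 (0.29 log units; within the scatter), stays within the scatter, so the two compounds are not separated. Compound 3 `C[C@@H](O[C@H]1CN2C(=O)C=C(C3CCOCC3)CC2[C@@H]1c1ccc(F)cc1)c1cc(C(F)(F)F)cc(C(F)(F)F)c1` carries oxan-4-yl in place of 3-ethyl-1,2,4-oxadiazol-5-yl on a double-bonded ring carbon. Among the compounds with values here, no measured step swaps an aromatic group on that carbon for a saturated ring, so the bearing of the one known step is indirect; its small size gives no ground to expect a large change. A modest shift upward, a 3.7-fold higher number from compound 2 to compound 3 (0.57 log units; beyond the scatter), is expected. Compound 3 is estimated at 100 nM, range 30 nM to 400 nM.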

Compound 3, half-maximal inhibitory concentration: 3.2 nM
Compound 3: middle estimate off by 31-fold (1.49 log units), on the high side; measured number outside the range, below it.
By their numbers in this assay, from the lowest: compound 3; then compounds 2 and 1 (each within the scatter of the next).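

In this assay, the double-bonded ring carbon proves sensitive to the group it carries, which the step between the two aromatic groups did not show: an 8.4-fold lower number from compound 2 to compound 3 (0.93 log units; beyond the scatter) and a 17-fold lower number from compound 1 to compound 3 (1.22 log units; beyond the scatter), each with oxan-4-yl entering. A six-membered non-aromatic ring is therefore accepted at this position, and compound 3 lies beyond the scatter of both other compounds. Nothing available accounts for this gain.

On these data alone, whether the ring oxygen of oxan-4-yl matters remains open: cyclohexyl, or piperidin-4-yl with its ring amine, on the same carbon would address this.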